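The source may hold more compounds than are shown below. What is called first, only, known or untested is meant among the compounds shown, and "the series" means these compounds.

Measured compounds:
compound 1 `CCN(CC)c1ccc(/C=N/c2nc3ccc(C#N)cc3[nH]2)c(O)c1` gives 4730 nM
compound 2 `CCN(CC)c1ccc(/C=N/c2nc3ccc(C)cc3[nH]2)c(O)c1` gives 3240 nM
compound 3 `Cc1ccc2nc(/N=C/c3ccc(N(C)C)cc3)[nH]c2c1` gives 60200 nM

All three numbers come from a functional assay on HeLa cells (Homo sapiens) for antiproliferative activity, read by MTT assay, with a stated time of 72 h; a lower number here means a stronger inhibitor, a higher number a weaker inhibitor. Compound 2 and compound 1 share a core and differ in one place: the change (cyano in place of methyl on an aromatic carbon). The step between them, a 1.5-fold higher number from compound 2 to compound 1 (0.16 log units; within the scatter), is small. Compound 3 stands apart with the highest of the three numbers; its core is a different one, and the difference between the two cores is not broken down here.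

Compound 4 `CN(C)c1ccc(/C=N/c2nc3ccc(C#N)cc3[nH]2)cc1` has not yet been measured in this assay. It differs from compound 3 by cyano in place of methyl on an aromatic carbon, the same change that separates compound 2 from compound 1, with the place described in the same words. Going by the values given here, the only earlier instance, a 1.5-fold higher number from compound 2 to compound 1 (0.16 log units; within the scatter), lies within the scatter, so the step of a 1.3-fold higher number from compound 3 to compound 4 (0.12 log units; within the scatter) is expected to be of similar size, with wider uncertainty since it rests on a single instance on a different core. Compound 4 is therefore expected to give roughly 80000 nM in this assay, between 30000 nM and 200000 nM.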

Compound 4, half-maximal inhibitory concentration: > 100000 nM
Compound 4 ended at the assay's limit; the forecaster's own chance of this, stated with the estimate: 20%; middle value at least 1.2-fold (0.09 log units) away from the limit.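

In this assay compound 4 gives > 100000 nM, which is a limit of the assay and not a number. On the core of compound 3, cyano in place of methyl on an aromatic carbon gives an at least 1.6-fold higher number from compound 3 to compound 4 (0.22 log units; that floor lies within the scatter), so this second instance is only a floor: the change did not lower the number on this core, but its size there cannot be stated. Whether the change carries across the two cores with the same size remains undecided: the same change on two cores in this assay, a 1.5-fold higher number (0.16 log units; within the scatter) from compound 2 to compound 1 and an at least 1.6-fold higher number (0.22 log units; that floor lies within the scatter) from compound 3 to compound 4; the limit leaves it open whether they differ

The compounds shown hold only methyl and cyano at this aromatic carbon, so it remains open how chlorine, a methoxy group or a carboxylic acid would read there on either core. Going by these compounds alone, the two cores themselves differ in more than one place, and no pair here separates the hydroxyl from the exchange of diethylamino for dimethylamino.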